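Amide change on a compound at the assay limit

The source may hold more compounds than are shown below. What is called first, only, known or untested is meant among the compounds shown, and "the series" means these compounds.

Compound 1 (`CCN(CC)CCCNC(=O)c1ccc(C(CC)(CC)c2ccc(OCC(O)C(C)(C)C)c(C)c2)n1CC`) gives 1100 nM in a functional assay on HepG2 cells (Homo sapiens), read by MTT assay, with a stated time of 48 h; a lower number here means a stronger inhibitor, a higher number a weaker inhibitor. Compound 2 (`C#CCNC(=O)c1ccc(C(CC)(CC)c2ccc(OCC(O)C(C)(C)C)c(C)c2)n1CC`) stands at > 50000 nM, which is a limit of this assay and not a number. Compound 3 (`CCn1c(C(=O)N(C)CCC#N)ccc1C(CC)(CC)c1ccc(OCC(O)C(C)(C)C)c(C)c1`) follows from compound 2 with (2-cyanoethyl)(methyl)amino in place of propargylamino on a carbonyl carbon. Among the measured compounds shown here, the one measured step that bears on this is an at least 45-fold higher number from compound 1 to compound 2 (1.65 log units; beyond the scatter), a large step beyond the scatter. Compound 3, like compound 2, lacks the 2-(diethylamino)ethyl group whose replacement produced that step, so no return towards compound 1 is assumed. No step beyond the scatter is expected in this assay, and a reading at the limit is likely. The expected change is an at least 1.2-fold lower number from compound 2 to compound 3 (0.09 log units; that floor lies within the scatter). For compound 3 the estimate is 40000 nM, within a range of 12000 nM to 100000 nM.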

Compound 3, half-maximal inhibitory concentration: > 50000 nM
Compound 3 ended at the assay's limit; the forecaster's own chance of this, stated with the estimate: 60%; middle value at least 1.2-fold (0.09 log units) from the limit.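

In this assay, replacing (3-(diethylamino)propyl)amino on the carbonyl carbon with (2-cyanoethyl)(methyl)amino gives an at least 45-fold higher number from compound 1 to compound 3 (1.65 log units; beyond the scatter), so a second group without the diethylamino end, this one also without the amide hydrogen, does not keep the reading of compound 1. Compound 3 reads > 50000 nM, which is a limit of the assay and not a number. The step from compound 2 to compound 3 cannot be read, and neither group can be ranked against the other: the limit of > 50000 nM in this assay, at which 2 of the 3 values shown sit.

Among the compounds shown here, compound 1 remains the only compound here with a number, so it stays open whether the diethylamino group or the length of the chain carries that reading. A propyl chain ending in a primary amine or a carboxylic acid at this position would separate the two.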